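The source may hold more compounds than are shown below. What is called first, only, known or untested is meant among the compounds shown, and "the series" means these compounds.

Working notes on the series. In a functional assay on MCF7 cells (Homo sapiens) for cytotoxicity, read by CellTiter-Glo, with a stated time of 5 days (on this read-out lower numbers stand for stronger inhibition and higher numbers for weaker inhibition), compound 3 `CC/C(=C(/c1ccc(/C=C/C(=O)O)cc1)c1ccc2[nH]ncc2c1C)c1ccccc1` gives 50 nM, the second highest of the three numbers in hand. Compound 1 `COCC/C(=C(/c1ccc(/C=C/C(=O)O)cc1)c1ccc2[nH]ncc2c1)c1ccccc1` gives 63 nM in this assay, a value within the scatter of compound 3; compound 2 `O=C(O)/C=C/c1ccc(/C(=C(/CCF)c2ccccc2)c2ccc3[nH]ncc3c2)cc1` gives 2.1 nM, far below both. Going by the values given here, the one single-point step measured so far, a 30-fold lower number from compound 1 to compound 2 (1.48 log units; beyond the scatter), concerns a substituent on the saturated chain and says nothing about the indazole. Compound 4 `CC/C(=C(/c1ccc(/C=C/C(=O)O)cc1)c1ccc2[nH]nc(Cl)c2c1)c1ccccc1` differs from compound 3 by 3-chloro-1H-indazol-5-yl in place of 4-methyl-1H-indazol-5-yl on a double-bonded chain carbon bound to an aromatic carbon and a double-bonded chain carbon. Among the compounds with values here, no measured step bears on that position, so the step of a 1.1-fold lower number from compound 3 to compound 4 (0.05 log units; within the scatter) is expected to stay within the scatter, with a wide margin. Compound 4 is therefore estimated at 45 nM in this assay, in a range from 10 nM to 200 nM.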

Compound 4, half-maximal inhibitory concentration: 284 nM
Compound 4: middle estimate off by 6.3-fold (0.80 log units), on the low side; the whole stated range lies below it.
By their numbers in this assay, from the lowest: compound 2; then compounds 3 and 1 (each within the scatter of the next); then compound 4.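

In this assay, the indazole group on a double-bonded chain carbon bound to an aromatic carbon and a double-bonded chain carbon proves sensitive to change: 3-chloro-1H-indazol-5-yl in place of 4-methyl-1H-indazol-5-yl gives a 5.7-fold higher number from compound 3 to compound 4 (0.75 log units; beyond the scatter). This single step removes the methyl and brings in the chlorine, and the share of each cannot be separated. Nothing in hand accounts for the shift. Open, from the compounds shown here alone, is how 4-chloro-1H-indazol-5-yl or 3-methyl-1H-indazol-5-yl would read here, which would split the step into its two parts. Also open, going by these compounds, is whether the same swap gives a similar step with the fluoroethyl chain of compound 2.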